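Ortho Chloro on the Arylpiperazine: Expected Potency of Compound 4

The compounds below may be only part of what the source reports. "The series", "measured", "known", "first", "only" and "open" are said of these compounds alone.

Measured compounds in a functional assay on the whole organism (strain CD-1) with Mus musculus as the target, in the maximal electroshock model, with a stated time of 0.5 h; on this read-out lower numbers stand for an effect already at smaller amounts and higher numbers for an effect only at larger amounts of compound:
Compound 1, `CC1(c2ccccc2)CC(=O)N(CC(=O)N2CCN(c3ccccc3F)CC2)C1=O`: 100 mg/kg
Compound 2, `CC1(c2ccccc2)CC(=O)N(CC(=O)N2CCN(c3cccc(Cl)c3)CC2)C1=O`: 300 mg/kg
Compound 3, `CC1(c2ccccc2)CC(=O)N(CC(=O)N2CCN(c3ccccc3)CC2)C1=O`: 300 mg/kg

Compound 3 carries a bare phenyl on the piperazine nitrogen. In this assay compound 3 sits level with compound 2, and together these two give the highest numbers of the three; compound 1 lies furthest from it, with a 3.0-fold higher number from compound 1 to compound 3 (0.48 log units; beyond the scatter) read in the opposite direction.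

Compound 4, `CC1(c2ccccc2)CC(=O)N(CC(=O)N2CCN(c3ccccc3Cl)CC2)C1=O`, differs from compound 3 in one place: chloro in place of hydrogen on an aromatic carbon

For the measured compounds named here, two measured steps bear on this change. The step of a 3.0-fold higher number from compound 1 to compound 3 (0.48 log units; beyond the scatter) shows that a halogen at this same place, ortho to a large group, moved the number in a modest way. The step of no change at the digits printed from compound 2 to compound 3 (within the scatter) shows that a chloro at another position of the same ring made no difference beyond the scatter. Compound 4 puts the heavier halogen at the position where fluoro helped in compound 1, so a modest lowering or no change beyond the scatter is expected, estimated as a 2.0-fold lower number from compound 3 to compound 4 (0.30 log units; within the scatter). For compound 4 the expected value is therefore 150 mg/kg, with a range from 60 mg/kg to 300 mg/kg.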

Compound 4, minimum effective dose: "not active" (no number reported)
Compound 4 has no reported number here; no gap can be computed for the estimate.
By their numbers in this assay, from the lowest: compound 1; then compounds 2 and 3 (each within the scatter of the next).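

In this assay, for the compounds shown here, compound 4 is reported as "not active" with no number, so no step from compound 3 to compound 4, or to any other compound, can be read. Nothing shown here accounts for this result. The compounds shown leave open how the 2-chlorophenyl of compound 4 truly compares with the bare phenyl of compound 3 on this read-out.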